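Acyl variation on the trimethoxyphenyl amide series

The source may hold more compounds than are shown below. What is called first, only, known or untested is meant among the compounds shown, and "the series" means these compounds.

Compound 1 `CCC/C=C/C(=O)N(Cc1ccc(OC)c(O)c1)c1cc(OC)c(OC)c(OC)c1` gives 95 nM in a functional assay on HCT-116 cells (Homo sapiens) for inhibition, read by MTT assay, with a stated time of 48 h (on this read-out lower numbers stand for stronger inhibition and higher numbers for weaker inhibition), the lowest of the three numbers measured. Compound 3 `C#CC(=O)N(Cc1ccc(OC)c(O)c1)c1cc(OC)c(OC)c(OC)c1` gives 310 nM; compound 2 `C/C=C/C(=O)N(Cc1cc(OC)c(OC)c(OC)c1)c1ccc(OC)c(O)c1`, with the two aryl groups exchanged, gives 8450 nM. Compound 4 `COc1ccc(CN(C(=O)CCCl)c2cc(OC)c(OC)c(OC)c2)cc1O` is not yet measured; it differs from compound 1 by 2-chloroethyl in place of pent-1-en-1-yl on a carbonyl carbon. Going by the values given here, the one step bearing on this is a 3.3-fold higher number from compound 1 to compound 3 (0.51 log units; beyond the scatter), where a different group also replaced pent-1-en-1-yl on the carbonyl carbon and the number rose modestly. Since the double bond outside aromatic rings leaves again, a loss of similar or somewhat larger size is expected. For compound 4 the estimate is 400 nM (range 120 nM to 1500 nM), which corresponds to an expected 4.2-fold higher number from compound 1 to compound 4 (0.62 log units; beyond the scatter).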

Compound 4, half-maximal inhibitory concentration: 150 nM
Compound 4: the middle estimate sits 2.7-fold (0.43 log units) above what was measured, within the range that was stated.
By their numbers in this assay, from the lowest: compounds 1 and 4 (each within the scatter of the next); then compound 3; then compound 2.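

With 2-chloroethyl on the carbonyl carbon, the double bond outside aromatic rings proves dispensable in this pair (a 1.6-fold higher number from compound 1 to compound 4 (0.20 log units; within the scatter)), unlike the earlier replacement by ethynyl. The two smaller groups also separate from each other (a 2.1-fold lower number from compound 3 to compound 4 (0.32 log units; beyond the scatter)), so the loss at compound 3 does not follow simply from removing pent-1-en-1-yl. Nothing available explains these differences.

On these data alone, whether the chlorine contributes remains open: a plain propyl group would test this. A longer chloroalkyl chain or an aminoalkyl group at this carbonyl carbon would show how far the position extends.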